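This account rests on a few compounds, and the source may have more. Where it says the series, first, only, none or still open, it means among the compounds named here.

For the measured compounds named here, in a functional assay on cells (Cancer cell lines, Homo sapiens) for cytotoxicity, read by sulforhodamine B assay, with a stated time of 48 h (on this read-out lower numbers stand for stronger inhibition of growth and higher numbers for weaker inhibition of growth), compound 2 `CC(=O)NS(=O)(=O)c1ccc(-n2nc(-c3ccccc3)cc2-c2cc(O)ccc2O)cc1` gives 100000 nM, which is the higher of the two numbers so far recorded. Compound 1 `NS(=O)(=O)c1ccc(-n2nc(-c3ccc(Cl)cc3)cc2-c2cc(O)ccc2O)cc1` gives 54500 nM in this assay; the two values lie within the scatter of each other, so no order can be drawn between them. Compound 3 `CC(=O)NS(=O)(=O)c1ccc(-n2nc(-c3ccc(Cl)cc3)cc2-c2cc(O)ccc2O)cc1` has not yet been measured in this assay. It differs from compound 2 in one place: chloro in place of hydrogen on an aromatic carbon. Compound 1 also carries this chloro group, together with a different sulfonamide, and its number does not separate from that of compound 2. Going by the values given here, no direct pair that isolates the chloro group alone has been measured, so the size of the step it brings is not known here. The expected step of a 1.4-fold lower number from compound 2 to compound 3 (0.15 log units; within the scatter) is therefore no more than the usual scatter, with perhaps a slight drift toward a lower number. Compound 3 is expected to give about 70000 nM, in a range from 30000 nM to 150000 nM in this assay.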

Compound 3, concentration for total growth inhibition: 82100 nM
For compound 3 the middle estimate is 1.2-fold (0.07 log units) below the measured one, within the range that was stated.
By their numbers in this assay, from the lowest: compounds 1, 3 and 2 (each within the scatter of the next).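

In this assay the change from phenyl to 4-chlorophenyl can now be read alone, and chloro in place of hydrogen gives a 1.2-fold lower number from compound 2 to compound 3 (0.09 log units; within the scatter) at this place on the ring, so the two compounds do not separate. Acetyl in place of hydrogen on the sulfonamide nitrogen can also be read alone for the first time, and with the chloro group held constant it gives a 1.5-fold higher number from compound 1 to compound 3 (0.18 log units; within the scatter) in the same assay, so this change does not separate its two compounds either. Nothing available here offers an explanation for either step.

Going by these compounds, whether a methoxy group or an amine in place of the chloro, or a longer acyl chain in place of the acetyl, would give a step beyond the scatter remains open. The compounds shown also leave open what the hydroxyl groups on the shared core contribute, since these are the same throughout.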